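Cytotoxicity notes: trifluoromethyl entering the shared core

A few compounds are considered here, and "the series" means these few. Any claim that something is new, unique, unknown or untested is made for them only; others in the source may bear on it.

Compound 1 `Cc1ccn2c(CCCCO)c(Cn3c(=O)n(C4CC4)c4ccncc43)nc2c1`: > 100000 nM
Compound 2 `O=c1n(Cc2nc3ccccn3c2CCCCO)c2cnccc2n1C1CC1`: > 100000 nM

In an ADME assay on HEp-2 cells (Homo sapiens) for cytotoxicity, read by CCK-8 assay, with a stated time of 6 days (on this read-out higher numbers stand for lower toxicity in this test and lower numbers for higher toxicity in this test), compound 1 gives only a limit, > 100000 nM. Compound 2 likewise gives only a limit, > 100000 nM. Within the data shown here, the one measured step, a step that the two limits leave unreadable from compound 1 to compound 2, hydrogen in place of methyl on an aromatic carbon, thus has no readable size. Compound 2 stands at the limit of this assay, as does every value shown: the limit of > 100000 nM in this assay, at which 2 of the 2 values shown sit.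

Compound 3 `O=c1n(Cc2nc3cc(C(F)(F)F)ccn3c2CCCCO)c2cnccc2n1C1CC1` differs from compound 2 by trifluoromethyl in place of hydrogen on an aromatic carbon. Among the measured compounds shown here, no measured step concerns a trifluoromethyl group, and the one step available, a step that the two limits leave unreadable from compound 1 to compound 2, was unreadable, so no step beyond the scatter is expected in this assay; the step of a number no higher from compound 2 to compound 3 (the limit leaves the size open) expected here rests on that alone. Compound 3 is expected at 100000 nM, between 30000 nM and 300000 nM, and is expected most likely to return again only a limit.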

Compound 3, half-maximal cytotoxic concentration: > 100000 nM
Compound 3: a limit, no number; the forecaster's own chance of this, stated with the estimate: 70%; the middle value lies on the limit itself.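

Compound 3 also gives only a limit, > 100000 nM, and no step among compound 1, compound 2 and compound 3 can be read in this assay: the limit of > 100000 nM in this assay, at which 3 of the 3 values shown sit.

The compounds shown leave open whether methyl, hydrogen or trifluoromethyl at this place makes any difference to the half-maximal cytotoxic concentration.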